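Hydrazone aryl group swap on a nucleoside adenosine ligand

This account rests on a few compounds, and the source may have more. Where it says the series, first, only, none or still open, it means among the compounds named here.

Compound 1 `Nc1nc(N/N=C/c2ccc3ncccc3c2)nc2c1ncn2[C@@H]1O[C@H](CO)[C@@H](O)[C@H]1O` gives 9.8 nM in an assay on CHO-K1 cells for displacement of a labelled ligand from adenosine receptor A1 (Homo sapiens), read by scintillation counting, with a stated time of 60 min; on this read-out higher numbers stand for weaker inhibition and lower numbers for stronger inhibition.
Compound 2 `CSCC/C=N/Nc1nc(N)c2ncn([C@@H]3O[C@H](CO)[C@@H](O)[C@H]3O)c2n1` gives only an assay limit, > 10000 nM.
Compound 3 `N#Cc1ccccc1/C=N/Nc1nc(N)c2ncn([C@@H]3O[C@H](CO)[C@@H](O)[C@H]3O)c2n1` gives 2.9 nM.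

Among the two numbers that are not limits, compound 3 stands lowest; the step of a 3.4-fold lower number from compound 1 to compound 3 (0.53 log units; beyond the scatter) separates it from its nearest neighbour. The value of compound 2 is a limit of the assay the limit of > 10000 nM in this assay, at which 1 of the 3 values shown sits, and not a number.

Compound 4 `Nc1nc(N/N=C/c2ccc[nH]2)nc2c1ncn2[C@@H]1O[C@H](CO)[C@@H](O)[C@H]1O` is the compound not yet measured. It differs from compound 3 in one place: 1H-pyrrol-2-yl in place of 2-cyanophenyl on a carbon with a double bond to nitrogen. Among the measured compounds shown here, two measured steps bear on this change, both at the same carbon with a double bond to nitrogen. One aromatic ring replaced by another gave the modest step of a 3.4-fold lower number from compound 1 to compound 3 (0.53 log units; beyond the scatter); an aromatic ring replaced by an open chain gave the large step of an at least 3400-fold lower number from compound 2 to compound 3 (3.53 log units; beyond the scatter). The group entering in compound 4 is again an aromatic ring, though a five-membered one with a hetero atom, so a step of the modest kind is expected rather than the large one, and upward is judged more likely than downward. Compound 4 is therefore expected to show a 5.2-fold higher number from compound 3 to compound 4 (0.71 log units; beyond the scatter) in this assay. The estimate for compound 4 is 15 nM, with a range from 3 nM to 80 nM.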

Compound 4, inhibition constant: 8 nM
For compound 4 the middle estimate is 1.9-fold (0.27 log units) above the measured one, within the range that was stated.
By their numbers in this assay, from the lowest: compound 3; then compounds 4 and 1 (each within the scatter of the next). At a limit, above all of these: compound 2.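

In this assay, a five-membered aromatic ring with 1 hetero atom on this carbon with a double bond to nitrogen gives a 2.8-fold higher number from compound 3 to compound 4 (0.44 log units; beyond the scatter), so a low number here is tied neither to a six-membered aromatic ring nor to the nitrile of 2-cyanophenyl; 1H-pyrrol-2-yl and quinolin-6-yl cannot be told apart, with a 1.2-fold lower number from compound 1 to compound 4 (0.09 log units; within the scatter). The open chain 2-(methylsulfanyl)ethyl now stands apart from all three aromatic groups, and the new comparison with it shows an at least 1200-fold lower number from compound 2 to compound 4 (3.09 log units; beyond the scatter). The value of compound 2 is a limit of the assay and not a number: the limit of > 10000 nM in this assay, at which 1 of the 4 values shown sits.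

The compounds leave open whether the hydrogen on the nitrogen of 1H-pyrrol-2-yl counts for anything, which a furan-2-yl or 1-methyl-1H-pyrrol-2-yl group on the same carbon would test. They also leave open where a saturated ring such as cyclohexyl or an open chain without sulfur such as pentyl would fall, compound 2 being the only open chain shown.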